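Ester Variation and Tolerance in a Cyclopentenone Series

This account rests on a few compounds, and the source may have more. Where it says the series, first, only, none or still open, it means among the compounds named here.

Measured compounds:
Compound 1 `CC/C=C\C[C@H]1C(=O)C=C[C@H]1CC(=O)Oc1ccccc1`: 158 uM
Compound 2 `CC/C=C\C[C@H]1C(=O)C=C[C@H]1CC(=O)OCc1ccccc1`: 31 uM

In an ADME assay on RAW264.7 cells (Mus musculus) for cytotoxicity, read by MTT assay, with a stated time of 24 h (a higher number here means that more compound is tolerated, a lower number that less compound is tolerated), compound 1 gives 158 uM, the higher of the two numbers. Going by the values given here, the only measured step, a 5.1-fold lower number from compound 1 to compound 2 (0.71 log units; beyond the scatter), shows a change on the ester oxygen lowering the number. Compound 3 `CC/C=C\C[C@H]1C(=O)C=C[C@H]1CC(=O)OCCOCCOC` carries a different change at the same place: 2-(2-methoxyethoxy)ethyl in place of phenyl on an oxygen next to a carbonyl group. Among the compounds with values here, no measured step involves such a chain, so the benzyl step gives only a weak pointer. Compound 3 is expected near compound 1, with a 1.1-fold lower number from compound 1 to compound 3 (0.02 log units; within the scatter), and is estimated at 150 uM, within a range of 60 uM to 400 uM.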

Compound 3, half-maximal toxic concentration: 161 uM
Compound 3: the middle estimate sits 1.1-fold (0.03 log units) below what was measured; the measured number falls inside the stated range.
By their numbers in this assay, from the lowest: compound 2; then compounds 1 and 3 (each within the scatter of the next).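

In this assay, 2-(2-methoxyethoxy)ethyl in place of phenyl on the oxygen gives a 1.0-fold higher number from compound 1 to compound 3 (0.01 log units; within the scatter), so an ester group with no ring matches the phenyl ester within the scatter. The same chain set against benzyl gives a 5.2-fold higher number from compound 2 to compound 3 (0.72 log units; beyond the scatter), which leaves compound 2 alone at the lower end and shows that losing the aromatic ring does not by itself lower the number. From the compounds shown here alone, whether an amine, a carboxylic acid or a longer chain of the same kind at this oxygen would stay with compound 1 and compound 3 or fall toward compound 2 remains open. No measurement offered here explains why benzyl stands apart.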